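A few compounds are considered here, and "the series" means these few. Any claim that something is new, unique, unknown or untested is made for them only; others in the source may bear on it.

Measured compounds:
- compound 1 `c1ccc(CCCCNC2CCc3ccsc3CC2)cc1`: 62 nM
- compound 2 `OCc1cc2c(s1)CCC(NCCCCc1ccccc1)CC2`: 84 nM
- compound 3 `Brc1cc2c(s1)CCC(NCCCc1ccccc1)CC2`: 41 nM

In an assay on membranes from brain for displacement of a labelled ligand from Sigma non-opioid intracellular receptor 1 (Cavia porcellus), read by scintillation counting, with a stated time of 120 min (on this read-out higher numbers stand for weaker inhibition and lower numbers for stronger inhibition), compound 3 gives 41 nM, the lowest of the three numbers. Compound 1 lies nearest, within the scatter of it, while compound 2 lies furthest, beyond the scatter. Among the measured compounds only one step differs in a single place: a 1.4-fold higher number from compound 1 to compound 2 (0.13 log units; within the scatter), which is within the scatter.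

Compound 4 `Brc1cc2c(s1)CCC(NCCCCc1ccccc1)CC2` differs from compound 3 by benzyl in place of phenyl on a saturated chain carbon, three bonds along the chain from an amine nitrogen. Going by the values given here, no measured step covers this change. Compound 1 and compound 2 both carry the benzyl on the chain carbon that compound 4 carries, but each differs from compound 3 in a second place as well, so what their values show cannot be separated into the chain change alone. What they do show is that their numbers and the number of compound 3 all sit close together in this assay, the spread from compound 3 to compound 2 being the only gap beyond the scatter.

Among the compounds with values here, with no direct precedent, the step from compound 3 to compound 4 is expected to be small, a 1.2-fold higher number from compound 3 to compound 4 (0.09 log units; within the scatter), in no fixed direction beyond the scatter. Compound 4 is therefore estimated at 50 nM, with a range from 18 nM to 140 nM.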

Compound 4, inhibition constant: 14 nM
For compound 4 the middle estimate is 3.6-fold (0.55 log units) above the measured one, outside the stated range (below it).
By their numbers in this assay, from the lowest: compound 4; then compounds 3, 1 and 2 (each within the scatter of the next, the first and the last beyond it).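

In this assay, going by these compounds alone, benzyl in place of phenyl on a saturated chain carbon, three bonds along the chain from an amine nitrogen, gives a 2.9-fold lower number from compound 3 to compound 4 (0.47 log units; beyond the scatter) and so lifts this chain position out of the scatter, a position for which no step had been available before. Among the compounds that carry the benzyl, the aromatic carbon also now shows steps beyond the scatter: bromo in place of hydrogen gives a 4.4-fold lower number from compound 1 to compound 4 (0.65 log units; beyond the scatter) and bromo in place of hydroxymethyl gives a 6.0-fold lower number from compound 2 to compound 4 (0.78 log units; beyond the scatter), whereas the earlier hydroxymethyl step stayed within the scatter. Nothing available here accounts for any of these steps.

Within the data shown here, the phenyl and benzyl pair is seen only with bromo on the aromatic carbon, so whether the chain step would hold with hydrogen or hydroxymethyl there remains open. Going by these compounds, it also remains open whether a still longer chain, or chloro or a nitrile in place of bromo, would take the number lower or give it back.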